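The source may hold more compounds than are shown below. What is called first, only, known or untested is meant among the compounds shown, and "the series" means these compounds.

Three measured compounds share one core. Compound 1 `O=c1cc(Cn2cc(CCCCl)nn2)c2ccc(O)cc2o1` carries a 3-chloropropyl on the five-membered ring and in a functional assay on HeLa cells (Homo sapiens) for inhibition, read by MTT assay, with a stated time of 72 h (a higher number here means a weaker inhibitor, a lower number a stronger inhibitor), compound 1 gives 49600 nM. Compound 2 `O=c1cc(Cn2cc(CCCO)nn2)c2ccc(O)cc2o1` gives 90200 nM in this assay, and compound 3 `CC(C)(C)c1cn(Cc2cc(=O)oc3cc(O)ccc23)nn1` gives 81100 nM. Compound 3 stands second highest of the three numbers; its nearest neighbour is compound 2 and its furthest is compound 1, and both gaps are within the scatter. The step of a 1.6-fold higher number from compound 1 to compound 3 (0.21 log units; within the scatter) and the step of a 1.1-fold lower number from compound 2 to compound 3 (0.05 log units; within the scatter) show that exchanging the group on this ring carbon has so far moved nothing beyond the scatter.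

Compound 4 `CCCCCCCCc1cn(Cc2cc(=O)oc3cc(O)ccc23)nn1` differs from compound 3 in that place: octyl in place of tert-butyl on an aromatic carbon. The two steps that bear on it, those ending in compound 3, were both small, so for compound 4 no step beyond the scatter is expected in this assay, with at most a slightly lower number as the chain grows. Going by the values given here, no measured compound carries a chain of this length, so the expectation rests on those two steps alone. Compound 4 is therefore estimated at 50000 nM, with a range from 15000 nM to 150000 nM, and the expected step is a 1.6-fold lower number from compound 3 to compound 4 (0.21 log units; within the scatter).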

Compound 4, half-maximal inhibitory concentration: 35100 nM
The estimate for compound 4 lay 1.4-fold (0.15 log units) above the measured number, within the range that was stated.
By their numbers in this assay, from the lowest: compounds 4, 1, 3 and 2 (each within the scatter of the next, the first and the last beyond it).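

In this assay, going by these compounds alone, changing the group on this aromatic carbon of the five-membered ring now gives steps beyond the scatter, which no step among the earlier compounds did: the step with octyl in place of tert-butyl is a 2.3-fold lower number from compound 3 to compound 4 (0.36 log units; beyond the scatter) and the step from the 3-hydroxypropyl compound is a 2.6-fold lower number from compound 2 to compound 4 (0.41 log units; beyond the scatter), both of them modest. The octyl chain does not separate from every earlier group, however, since the step from the 3-chloropropyl compound is a 1.4-fold lower number from compound 1 to compound 4 (0.15 log units; within the scatter), so that any gain from octyl holds against only two of the three earlier groups. Nothing at hand explains these differences.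

The compounds shown leave open whether the step from tert-butyl follows the added carbons or the change from a branched group to a straight chain, which a straight butyl or a hexyl on the same carbon could separate. They also leave open whether a chain longer than octyl, or a propyl chain ending in an amine or a carboxylic acid, would move the number further in this assay.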